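The source may report more compounds than this note shows. Statements on the series, on what has been measured and on what is new or still open speak of the compounds shown alone.

In a functional assay on SW-620 cells (Homo sapiens) for cytotoxicity, read by MTT assay, with a stated time of 72 h (on this read-out lower numbers stand for stronger inhibition and higher numbers for weaker inhibition), compound 1 `COc1cccc(/C=C2\CCC/C(=C\c3ccc(Br)cc3)C2=O)c1OC` gives 11100 nM and compound 3 `COc1ccc(/C=C2\CCC/C(=C\c3cccc(OC)c3OC)C2=O)cc1` gives 13600 nM. These two sit together, with a 1.2-fold higher number from compound 1 to compound 3 (0.09 log units; within the scatter). Compound 2 `COc1ccccc1/C=C1\CCC/C(=C\c2cccc(OC)c2OC)C1=O` reads > 20000 nM, which is a limit of the assay. Compound 4 `COc1ccc(/C=C2\CCC/C(=C\c3cccc(OC)c3OC)C2=O)c(OC)c1` departs from compound 3 by methoxy in place of hydrogen on an aromatic carbon. The closest guide is the swap of 2-methoxyphenyl for 4-methoxyphenyl, which gave an at least 1.4-fold lower number from compound 2 to compound 3 (0.16 log units; that floor lies within the scatter). Compound 4 keeps the methoxy of compound 3 and adds another on that ring, and the steps measured so far are all small. The expected step is a 1.1-fold higher number from compound 3 to compound 4 (0.04 log units; within the scatter), leaning towards a higher number. For compound 4 the estimate is 15000 nM, with an expected range of 8000 nM to 28000 nM.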

Compound 4, half-maximal inhibitory concentration: > 20000 nM
Compound 4 was reported as a limit; the forecaster's own chance of this, stated with the estimate: 30%; middle value at least 1.3-fold (0.12 log units) away from the limit.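

Methoxy in place of hydrogen, ortho to a large group on this ring, gives an at least 1.4-fold higher number from compound 3 to compound 4 (0.16 log units; that floor lies within the scatter). Compound 4 and compound 2 both carry a methoxy group at this place, and both read as a limit, not a number: the limit of > 20000 nM in this assay, at which 2 of the 4 values shown sit. Compound 3 lacks this group and gives a measured number, but the step between compound 2 and compound 4 cannot be read. On these data alone, how far compound 4 lies past its limit stays open. So does how a hydroxyl group or an amine on this same carbon would read in this assay.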